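The compounds below may be only part of what the source reports. "The series", "measured", "known", "first", "only" and "open" are said of these compounds alone.

Compound 1 `N#Cc1c(-c2ccc(Br)cc2)nc2cnccc2c1NCC(N)=O`, compound 3 `CC(Nc1c(C#N)c(-c2ccc(Br)cc2)nc2cnccc12)C(N)=O` and compound 2 `CCCCC(Nc1c(C#N)c(-c2ccc(-c3ccccc3OCC)cc2)nc2cnccc12)C(N)=O` share one core and differ at a saturated chain carbon bound to a carbonyl carbon and a nitrogen on an aromatic ring. In a physicochemical assay for lipophilicity, read by HPLC, at pH 7.5 (on this read-out lower numbers stand for lower lipophilicity and higher numbers for higher lipophilicity), compound 1 gives 1.9, compound 3 gives 2.1, and compound 2 gives 3.6, the highest of the three. For the measured compounds named here, the only single-change step measured, a number 0.20 log units higher from compound 1 to compound 3 (within the scatter), concerns the same place. Compound 4 `CCOc1ccccc1-c1ccc(-c2nc3cnccc3c(NC(C(N)=O)C3CC3)c2C#N)cc1` differs from compound 2 by cyclopropyl in place of butyl on a saturated chain carbon bound to a carbonyl carbon and a nitrogen on an aromatic ring. Because the step of a number 0.20 log units higher from compound 1 to compound 3 (within the scatter) was small, this larger exchange, in which the entering group carries fewer carbons than the leaving one, is expected to move the read-out downward. The expected step is a number 0.60 log units lower from compound 2 to compound 4 (beyond the scatter). Compound 4 is therefore estimated at 3, between 2.6 and 3.4.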

Compound 4, distribution coefficient: 3
Estimate against measurement, compound 4: no gap at the digits printed; measured number inside the range.
By their numbers in this assay, from the lowest: compounds 1 and 3 (each within the scatter of the next); then compound 4; then compound 2.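

Putting cyclopropyl in place of butyl on the saturated chain carbon gives, in this assay, a number 0.60 log units lower from compound 2 to compound 4 (beyond the scatter), the only step shown at this place that lies beyond the scatter. The number here can therefore shift with the group on this carbon, and in this pair the group with fewer carbons, which also carries a ring, reads lower. No measurement shown gives a reason for this step. Still open, on these data alone, is whether the ring or the carbon count matters more, which a propyl chain here could separate. As far as these compounds go, how an amine or a carboxylic acid at this place would read also remains open.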